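The source may report more compounds than this note shows. Statements on the series, on what has been measured and on what is new or still open speak of the compounds shown alone.

Measured in a functional assay on L1210 cells (Mus musculus) for inhibition; on this read-out higher numbers stand for weaker inhibition and lower numbers for stronger inhibition:
- compound 1 `O=C1CCCCC/C1=C\c1ccc(F)cc1`: 291000 nM
- compound 2 `O=C1CCCCC/C1=C\c1ccc(Cl)cc1`: 83000 nM

Compound 2 holds the lower of the two numbers, 83000 nM. Next is compound 3 `O=C1CCCCC/C1=C\c1ccc(Br)cc1`, with the change bromo in place of chloro on an aromatic carbon. Among the measured compounds shown here, only one measured step bears on this, a 3.5-fold lower number from compound 1 to compound 2 (0.54 log units; beyond the scatter), a modest one with chloro in place of fluoro. A single step sets no trend, so a smaller move towards a lower number in this assay is expected, possibly within the scatter. The expected step is a 1.4-fold lower number from compound 2 to compound 3 (0.14 log units; within the scatter). For compound 3 the estimate is 60000 nM, with an expected range of 25000 nM to 150000 nM.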

Compound 3, half-maximal inhibitory concentration: 68400 nM
Compound 3: the middle estimate sits 1.1-fold (0.06 log units) below what was measured; low and high end bracket the measured number.
By their numbers in this assay, from the lowest: compounds 3 and 2 (each within the scatter of the next); then compound 1.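

In this assay, bromo in place of chloro at this position gives a 1.2-fold lower number from compound 2 to compound 3 (0.08 log units; within the scatter), so these two halogens cannot be told apart here, while bromo in place of fluoro gives a 4.3-fold lower number from compound 1 to compound 3 (0.63 log units; beyond the scatter). The separation among these three compounds therefore sets fluoro apart from chloro and bromo and shows no graded run through all three. Nothing available explains this pattern.

As far as these compounds go, whether iodo would sit with chloro and bromo remains open. So does whether an amine or a carboxylic acid on this aromatic carbon would move the number beyond the scatter.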